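Aminopyrazole to hydroxymethylpyridinyl on the shared core

The source may report more compounds than this note shows. Statements on the series, on what has been measured and on what is new or still open speak of the compounds shown alone.

Compound 1 `CN(c1ccn(C)n1)c1cnc(NCc2c(F)ccc3c2CCO3)c2cn[nH]c(=O)c12` is the more polar of the two measured entries: in a physicochemical assay for lipophilicity, using the shake flask method, in phosphate buffer, measured as octanol-water partition, with a stated time of 30 min, at pH 7.4 (a higher number here means a more lipophilic compound, a lower number a more polar compound), compound 1 gives 2.4, while compound 2 `Fc1ccc2c(c1CNc1ncc(Nc3ccccc3)c3nncn13)CCO2` gives 3.3, a gap beyond the scatter. Compound 2 is built on a different core, so its value marks only a neighbour on the scale, not a step from compound 1.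

Compound 3 `Cc1nc(CO)ccc1-c1cnc(NCc2c(F)ccc3c2CCO3)c2cn[nH]c(=O)c12` keeps the core of compound 1 and differs in one place: 6-(hydroxymethyl)-2-methylpyridin-3-yl in place of methyl(1-methyl-1H-pyrazol-3-yl)amino on an aromatic carbon. A group with no hydrogen-bond donor and three acceptors leaves; a group with one donor, two acceptors and one more heavy atom enters, an aryl link replacing an amino link. Within the data shown here, no measured pair shows what such a swap does to the distribution coefficient here. The estimate for compound 3 is therefore close to compound 1, at 2.5, with a range from 1.9 to 3.1. The expected step is a number 0.10 log units higher from compound 1 to compound 3 (within the scatter), not clearly beyond the scatter in either direction.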

Compound 3, distribution coefficient: 2.4
Estimate against measurement, compound 3: 0.10 log units above, and the stated range covers the measured number.
By their numbers in this assay, from the lowest: compounds 1 and 3 (each within the scatter of the next); then compound 2.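

In this assay, 6-(hydroxymethyl)-2-methylpyridin-3-yl in place of methyl(1-methyl-1H-pyrazol-3-yl)amino on this aromatic carbon gives no change at the digits printed from compound 1 to compound 3 (within the scatter). Among these compounds, this is the first one-place comparison on the shared core, and it shows that a six-membered aromatic ring with a hydrogen-bond donor in the entering group and a five-membered aromatic ring on an amino link cannot be told apart by this read-out at this position. No separate measurement bears on this result.

The ring, the link and the hydroxymethyl group all change in this single step, so the contribution of each remains unresolved. Also open, as far as these compounds go, is where the distribution coefficient would fall with a carboxylic acid or a primary amine in place of the hydroxymethyl group, or with a longer chain at that point.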